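The compounds below may be only part of what the source reports. "The series", "measured", "known", "first", "only" and "open" are said of these compounds alone.

In an ADME assay on HepG2 cells (Homo sapiens) for cytotoxicity, read by MTT assay, with a stated time of 72 h (a lower number here means that less compound is tolerated, a higher number that more compound is tolerated), compound 1 `COc1ccc(C#Cc2cc(Cl)cn3c([N+](=O)[O-])c(CS(=O)(=O)c4ccccc4)nc23)cc1` gives > 3900 nM, which is a limit of the assay and not a number. Compound 2 `O=[N+]([O-])c1c(CS(=O)(=O)c2ccccc2)nc2c(C#Cc3ccc(F)cc3)cc(Cl)cn12` gives > 3900 nM, again a limit. Compound 3 `O=[N+]([O-])c1c(CS(=O)(=O)c2ccccc2)nc2c(C#Cc3cccnc3)cc(Cl)cn12` gives > 3900 nM, also a limit. The picture so far is therefore (the limit of > 3900 nM in this assay, at which 3 of the 3 values shown sit), and compound 3 has no exact value to start from.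

Compound 4 `CC(O)(C#Cc1cc(Cl)cn2c([N+](=O)[O-])c(CS(=O)(=O)c3ccccc3)nc12)c1ccccc1` differs from compound 3 at one place: 1-hydroxy-1-phenylethyl stands in place of pyridin-3-yl on a triple-bonded carbon, (1-hydroxy-1-phenylethyl in place of pyridin-3-yl on a triple-bonded carbon). Unlike the pyridin-3-yl group, the entering group brings a hydrogen-bond donor.

Among the compounds with values here, three measured steps bear on this. Fluoro in place of methoxy on an aromatic carbon gives a step that the two limits leave unreadable from compound 1 to compound 2. Two changes at the triple-bonded carbon itself are closer to the new one: pyridin-3-yl in place of 4-methoxyphenyl gives a step that the two limits leave unreadable from compound 1 to compound 3, and pyridin-3-yl in place of 4-fluorophenyl gives a step that the two limits leave unreadable from compound 2 to compound 3. None of these steps has a readable size, so none points in a direction. No step beyond the scatter is therefore expected in this assay, and another limit is the likeliest report. The expected step is a step that the limit leaves unreadable from compound 3 to compound 4. For compound 4 the estimate is 5000 nM, with an expected range from 2500 nM to 20000 nM.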

Compound 4, half-maximal cytotoxic concentration: 18800 nM
Beside the measured number, compound 4's estimate is 3.8-fold (0.58 log units) below it; measured number inside the range.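

Compound 4 has an exact value, but no step from compound 1, compound 2 or compound 3 to compound 4 can be read, because each of those three compounds gives only a limit: the limit of > 3900 nM in this assay, at which 3 of the 4 values shown sit.

The compounds shown leave open whether 1-hydroxy-1-phenylethyl, pyridin-3-yl, 4-fluorophenyl and 4-methoxyphenyl on the triple-bonded carbon differ at all in this assay.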